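The source may hold more compounds than are shown below. What is called first, only, known or untested is meant among the compounds shown, and "the series" means these compounds.

In a functional assay on ECa-109 cells for antiproliferative activity against ECa-109 cell line (Homo sapiens), read by MTT assay, with a stated time of 48 h (on this read-out higher numbers stand for weaker inhibition and lower numbers for stronger inhibition), compound 1 `COc1ccc(CN(C(=O)CCSc2nc3ccccc3o2)c2cc(OC)c(OC)c(OC)c2)cc1` gives 12600 nM, level within the scatter with compound 2 `COc1ccc(CN(C(=O)CCCSc2nc3ccccc3o2)c2cc(OC)c(OC)c(OC)c2)cc1` at 11000 nM and compound 3 `COc1ccc(CN(C(=O)CCCCSc2nc3ccccc3o2)c2cc(OC)c(OC)c(OC)c2)cc1` at 7650 nM. Compound 4 `COc1ccc(CN(C(=O)CSc2nc3ccccc3[nH]2)c2cc(OC)c(OC)c(OC)c2)cc1` differs from compound 1 by (1H-benzimidazol-2-yl)sulfanyl in place of ((1,3-benzoxazol-2-yl)sulfanyl)methyl on a saturated chain carbon bound to a carbonyl carbon. The chain steps bear on this change: a 1.1-fold lower number from compound 1 to compound 2 (0.06 log units; within the scatter), a 1.6-fold lower number from compound 1 to compound 3 (0.22 log units; within the scatter) and a 1.4-fold lower number from compound 2 to compound 3 (0.16 log units; within the scatter). All stay within the scatter, so chain length alone suggests no real shift. Going by the values given here, no measured step covers the new ring group, which keeps the range wide. The expected change is a 1.4-fold lower number from compound 1 to compound 4 (0.15 log units; within the scatter), with no clear step beyond the scatter. Compound 4 is estimated at 9000 nM, with an expected range of 2500 nM to 30000 nM.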

Compound 4, half-maximal inhibitory concentration: 42600 nM
The estimate for compound 4 lay 4.7-fold (0.68 log units) below the measured number; the whole stated range lies below it.
By their numbers in this assay, from the lowest: compounds 3, 2 and 1 (each within the scatter of the next); then compound 4.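

Chain length alone stayed within the scatter among compounds 1, 2 and 3, but this change on a saturated chain carbon bound to a carbonyl carbon moves this assay beyond it, with a 3.4-fold higher number from compound 1 to compound 4 (0.53 log units; beyond the scatter) and a 3.9-fold higher number from compound 2 to compound 4 (0.59 log units; beyond the scatter) as the steps. The entering (1H-benzimidazol-2-yl)sulfanyl group adds a hydrogen-bond donor, and the chain changes with it. Nothing measured here gives a reason for the weaker inhibition.

As far as these compounds go, it remains open whether the ring or the chain length carries the step. (1,3-Benzoxazol-2-yl)sulfanyl on the chain of compound 4 would separate them, and an amine in that place would test a different group.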